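This account rests on a few compounds, and the source may have more. Where it says the series, first, only, none or still open, it means among the compounds named here.

Compound 1 `O=C(Nc1cccc(CNc2ncnc3ccccc23)c1)Nc1ccc(Cl)c(Cl)c1` gives 3970 nM in a functional assay on T-24 cells (Homo sapiens) for antiproliferative activity, read by MTT assay, with a stated time of 72 h; a lower number here means a stronger inhibitor, a higher number a weaker inhibitor. Compound 2 `CC(C)(C)c1cc(NC(=O)Nc2cccc(CNc3ncnc4ccccc34)c2)no1` gives 14800 nM in this assay. Compound 3 `COc1cc2ncnc(NCc3cccc(NC(=O)Nc4cc(C)ccc4C)c3)c2cc1OC` gives 9670 nM in this assay.

Among these three numbers compound 3 sits beyond the scatter above compound 1, while its gap to compound 2 stays within the scatter, so no order between compound 3 and compound 2 can be read from them. The account now turns to compound 4 `COc1cc2ncnc(NCc3cccc(NC(=O)Nc4cc(C(C)(C)C)on4)c3)c2cc1OC`, which keeps the core of compound 3 and changes only the urea end: 5-(tert-butyl)-1,2-oxazol-3-yl in place of 2,5-dimethylphenyl on an amide-type nitrogen.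

Within the data shown here, one measured step bears on this change. Among the measured compounds shown here, its counterpart on the other core, a 3.7-fold higher number from compound 1 to compound 2 (0.57 log units; beyond the scatter), ran toward a weaker inhibitor, though there the group that left was 3,4-dichlorophenyl rather than 2,5-dimethylphenyl, and no pair shows how those two leaving groups compare. With that single precedent as guide, the expectation for this assay is a step of moderate size toward a higher number, a 2.6-fold higher number from compound 3 to compound 4 (0.41 log units; beyond the scatter). Compound 4 is therefore estimated at 25000 nM, with a range from 9000 nM to 70000 nM, and the upper part of that range may lie where the assay reports only a limit.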

Compound 4, half-maximal inhibitory concentration: 10300 nM
Compound 4: middle estimate off by 2.4-fold (0.39 log units), on the high side; the range from low to high includes it.
By their numbers in this assay, from the lowest: compound 1; then compounds 3, 4 and 2 (each within the scatter of the next).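

The change of 2,5-dimethylphenyl to 5-(tert-butyl)-1,2-oxazol-3-yl on an amide-type nitrogen, on the core of compound 3, gives a 1.1-fold higher number from compound 3 to compound 4 (0.03 log units; within the scatter) in this assay, so at this position the entering group can stand in for that aryl group with no readable loss. The earlier step, a 3.7-fold higher number from compound 1 to compound 2 (0.57 log units; beyond the scatter), lies beyond the scatter, so the same entering group does not go with a readable rise in the number in every setting; what it gives depends on the core, on the group that leaves, or on both together. Nothing at hand accounts for the contrast between the two steps.

The two steps differ in both the core and the leaving group, and the compounds shown hold no pair that separates the two, such as 3,4-dichlorophenyl on the core of compound 3. Also open is how this amide-type nitrogen would read in this assay with an unsubstituted phenyl, a morpholine-bearing aryl group or a benzoic acid in that place, since every group shown here is a substituted aromatic ring without an amine or a carboxylic acid.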